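Swapping the aryl group on a shared quinoline-ether core

The source may report more compounds than this note shows. Statements on the series, on what has been measured and on what is new or still open speak of the compounds shown alone.

Compound 1 `COc1cc2c(Oc3ccc(NC(=O)c4nccc(-c5ccc(C)cc5)n4)cc3F)ccnc2cc1OCCCN1CCCCC1`: in a functional assay on NCI-H460 cells (Homo sapiens) for cytotoxicity, read by MTT assay, with a stated time of 72 h (on this read-out higher numbers stand for weaker inhibition and lower numbers for stronger inhibition), compound 1 gives 230 nM
Compound 2 `COc1cc2c(Oc3ccc(NC(=O)c4nccc(-c5ccc(C)cc5)n4)cc3F)ccnc2cc1OCCCN1CCN(C)CC1`: in this assay compound 2 gives 160 nM

Both compounds share the same core and differ only in the amine at the end of the three-carbon chain. The step of a 1.4-fold lower number from compound 1 to compound 2 (0.16 log units; within the scatter) is small, so compound 2 and compound 1 cannot be told apart on these numbers; compound 2 simply has the lower of the two readings.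

Compound 3 `COc1cc2c(Oc3ccc(NC(=O)c4nccc(-c5ccc(F)cc5F)n4)cc3F)ccnc2cc1OCCCN1CCN(C)CC1` is not yet measured. It keeps the chain amine of compound 2 and changes the aryl group on the core: 2,4-difluorophenyl in place of 4-methylphenyl on an aromatic carbon. Among the compounds with values here, no measured step touches this position; the only step available concerns the chain amine, which is unchanged here. Nothing therefore points to a shift in either direction in this assay beyond the scatter. Compound 3 is expected to give about 200 nM, with a range from 60 nM to 700 nM, which is a step of a 1.3-fold higher number from compound 2 to compound 3 (0.10 log units; within the scatter) and is widened for want of any guide.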

Compound 3, half-maximal inhibitory concentration: 450 nM
Compound 3: the middle estimate sits 2.3-fold (0.35 log units) below what was measured; measured number inside the range.
By their numbers in this assay, from the lowest: compounds 2, 1 and 3 (each within the scatter of the next, the first and the last beyond it).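

In this assay, the aryl group on the shared core proves able to move the reading: 2,4-difluorophenyl in place of 4-methylphenyl gives a modest step (a 2.8-fold higher number from compound 2 to compound 3 (0.45 log units; beyond the scatter)) that lies beyond the scatter, towards weaker inhibition. Within the data shown here, the earlier change of chain amine stayed within the scatter, so this position, on an aromatic carbon next to the ring nitrogen, is the first place where a single change gives a readable difference. No measurement shown here explains this step.

The swap removes a methyl and adds two fluorines at once, so these compounds cannot separate the effect of each; a plain phenyl or a 4-fluorophenyl at this position would help. From the compounds shown here alone, whether the step also holds with piperidin-1-yl at the chain end remains open.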